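This account rests on a few compounds, and the source may have more. Where it says the series, first, only, none or still open, it means among the compounds named here.

Measured compounds:
Compound 1 `Cc1cc(S(=O)(=O)/N=C(\N)n2nccc2-c2ccccc2)c(SCc2cccc3ccccc23)cc1Cl`: 0.268 h
Compound 2 `Cc1cc(S(=O)(=O)/N=C(\N)n2nccc2-c2ccccc2)c(SCc2cccc(C(F)(F)F)c2)cc1Cl`: 0.0863 h

In an ADME assay on microsomes from liver (Homo sapiens) for metabolic stability, read by LC-MS, using NADPH, tested at 5 uM (a higher number here means that the compound lasts longer, a lower number that the compound disappears faster), compound 2 holds the lowest of the two numbers; its nearest neighbour, compound 1, gives 0.268 h. Compound 3 `Cc1ccc(CSc2cc(Cl)c(C)cc2S(=O)(=O)/N=C(\N)n2nccc2-c2ccccc2)cc1` differs from compound 2 by 4-methylphenyl in place of 3-(trifluoromethyl)phenyl on a saturated chain carbon bound to a sulfur. Within the data shown here, the one measured step at this position, a 3.1-fold lower number from compound 1 to compound 2 (0.49 log units; beyond the scatter), shows that swapping the aryl group on this carbon can move the half-life beyond the scatter, though it offers no direct guide for a 4-methylphenyl group. Compound 3 is therefore expected to land near compound 2, with a shift of a 1.4-fold higher number from compound 2 to compound 3 (0.14 log units; within the scatter) plausible. Compound 3 is estimated at 0.12 h, ranging from 0.05 h to 0.3 h.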

Compound 3, half-life: 0.13 h
Compound 3: middle estimate off by 1.1-fold (0.03 log units), on the low side; the range from low to high includes it.
By their numbers in this assay, from the lowest: compounds 2 and 3 (each within the scatter of the next); then compound 1.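

In this assay, 4-methylphenyl in place of 3-(trifluoromethyl)phenyl on a saturated chain carbon bound to a sulfur gives a 1.5-fold higher number from compound 2 to compound 3 (0.18 log units; within the scatter) and so does not separate these two groups. Set against naphthalen-1-yl, 4-methylphenyl gives a 2.1-fold lower number from compound 1 to compound 3 (0.31 log units; beyond the scatter) and so, like 3-(trifluoromethyl)phenyl, stands modestly apart from it. No supporting data offer an explanation for this difference. The compounds shown leave open how an amine or a carboxylic acid on the aryl group would read, and whether a longer chain at this carbon would change the half-life.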